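This account rests on a few compounds, and the source may have more. Where it says the series, first, only, none or still open, it means among the compounds named here.

Of the compounds shown here, three with a shared core have been measured in a physicochemical assay for lipophilicity, using the shake flask method, in phosphate buffer, measured as octanol-water partition, with a stated time of 24 h, at pH 7.4; on this read-out higher numbers stand for higher lipophilicity and lower numbers for lower lipophilicity. Compound 2 `COc1ccc(-c2nn(-c3ccccc3F)c3c2CCS(=O)(=O)O3)cc1` gives 2.62. Compound 1 `O=S1(=O)CCc2c(C3CC3)nn(-c3ccccc3F)c2O1` gives 2.09, and compound 3 `COc1ccc(-c2nn(-c3ccccc3F)c3c2C(c2ccc(Br)c(C)c2)CS(=O)(=O)O3)cc1` gives 2.91. Compound 2 thus stands clearly above one neighbour but cannot be told apart from the other.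

Compound 4 `COc1ccc(-c2nn(-c3ccccc3Cl)c3c2CCS(=O)(=O)O3)cc1` has one change from compound 2: chloro in place of fluoro on an aromatic carbon, ortho to a large group (chloro in place of fluoro on an aromatic carbon).

Among the compounds with values here, no measured step makes this exact swap, so the two available steps offer only loose guidance. With 4-methoxyphenyl in place of cyclopropyl on an aromatic carbon, the result was a number 0.53 log units higher from compound 1 to compound 2 (beyond the scatter). With 4-bromo-3-methylphenyl in place of hydrogen on a saturated ring carbon, it was a number 0.29 log units higher from compound 2 to compound 3 (within the scatter). Both exchanges involve more of the structure than this swap does, so a small upward step, not beyond the scatter, is expected in this assay.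

The expected change is a number 0.28 log units higher from compound 2 to compound 4 (within the scatter). The estimate for compound 4 is 2.9, with an expected range from 2.6 to 3.2.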

Compound 4, partition coefficient: 3.04
The estimate for compound 4 lay 0.14 log units below the measured number; low and high end bracket the measured number.
By their numbers in this assay, from the lowest: compound 1; then compounds 2, 3 and 4 (each within the scatter of the next, the first and the last beyond it).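

Exchanging fluoro for chloro on an aromatic carbon, ortho to a large group, gives in this assay a number 0.42 log units higher from compound 2 to compound 4 (beyond the scatter), so this one place on the shared core has a clear effect on the read-out. Within the data shown here, the swap replaces a single heavy atom with a single heavy atom and leaves the counts of rings, hydrogen-bond donors and hydrogen-bond acceptors unchanged, whereas the earlier steps exchanged or added whole groups. One of those larger changes gave only a number 0.29 log units higher from compound 2 to compound 3 (within the scatter), so among these compounds the size of a structural change does not tell how far the number moves.

On these data alone, it remains open how an amine or a carboxylic acid at this same place would read, and whether the swap from fluoro to chloro gives a similar step with the cyclopropyl of compound 1 in place of the 4-methoxyphenyl. No measurement shown here offers an explanation for the step.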